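Para-chloro on the sulfonyl phenyl: compound 3 to compound 4

This account rests on a few compounds, and the source may have more. Where it says the series, first, only, none or still open, it means among the compounds named here.

Of the compounds shown here, three built on one shared core have been measured in an assay on HeLa cells for displacement of a labelled ligand from 5-hydroxytryptamine receptor 6 (Homo sapiens); a lower number here means a stronger inhibitor, a higher number a weaker inhibitor. Compound 1 `O=S(=O)(c1ccccn1)n1ccc2c(N3CCNCC3)cccc21` gives 1 nM, compound 2 `O=S(=O)(c1cccc(Cl)c1)n1ccc2c(N3CCNCC3)ccc(Cl)c21` gives 0.316 nM, and compound 3 `O=S(=O)(c1ccccc1)n1ccc2c(N3CCNCC3)c(Cl)ccc21` gives 1.59 nM. Compound 3 thus carries the highest number of the three; its gap to compound 1 lies within the scatter, while compound 2 sits beyond the scatter with a clearly lower number.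

Compound 4 `O=S(=O)(c1ccc(Cl)cc1)n1ccc2c(N3CCNCC3)c(Cl)ccc21` differs from compound 3 in one place: chloro in place of hydrogen on an aromatic carbon. For the measured compounds named here, no measured pair in this set shows this exact change on its own. Going by the values given here, compound 2, the only compound carrying a chloro on the sulfonyl-linked phenyl, returns the lowest number, but it also differs from compound 3 elsewhere, so it cannot be read as a clean precedent. Compound 4 is therefore expected to show a modest step downward in this assay, estimated as a 1.8-fold lower number from compound 3 to compound 4 (0.25 log units; within the scatter), not certainly beyond the scatter. The expected value for compound 4 is 0.9 nM, with a range from 0.3 nM to 2.5 nM.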

Compound 4, inhibition constant: 6.31 nM
Compound 4: middle estimate off by 7.0-fold (0.85 log units), on the low side; the whole stated range lies below it.
By their numbers in this assay, from the lowest: compound 2; then compounds 1 and 3 (each within the scatter of the next); then compound 4.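

In this assay, for the compounds shown here, the change from phenyl to 4-chlorophenyl gives a 4.0-fold higher number from compound 3 to compound 4 (0.60 log units; beyond the scatter), the first step in this set that can be read at a single place, and it runs toward weaker inhibition. With the rest of compound 3 held fixed, chloro on this aromatic carbon, para to a large group, therefore carries a cost rather than the small gain that hydrogen-to-chloro might have seemed to offer. Nothing measured here bears on the reason for this loss.

From the compounds shown here alone, it remains open whether the cost belongs to chloro itself or would also follow fluoro, methoxy or an amine on the same carbon. Also open, going by these compounds, is whether the same change would cost as much if the chloro on the core of compound 3 were absent.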